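Replacing cyclopropyl with methyl on an amide-type nitrogen

The source may report more compounds than this note shows. Statements on the series, on what has been measured and on what is new or still open speak of the compounds shown alone.

Compound 1 `CCN(CC)C(=S)SCC1=CCOC1=O` gives 57100 nM
Compound 2 `CCNC(=S)SCC1=CCOC1=O` gives 30600 nM
Compound 3 `O=C1OCC=C1CSC(=S)NC1CC1` gives 117000 nM

All three values were read in a functional assay on PC-3 cells (Homo sapiens) for antiproliferative activity, read by MTT assay, with a stated time of 72 h (a higher number here means a weaker inhibitor, a lower number a stronger inhibitor), and compound 3 has the highest number of the set, which makes it the weakest inhibitor so far. Compound 4 `CNC(=S)SCC1=CCOC1=O` has not yet been measured. It differs from compound 3 in one place, where the change methyl in place of cyclopropyl on an amide-type nitrogen amounts to methyl in place of cyclopropyl on an amide-type nitrogen.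

Two measured steps involve cyclopropyl. The closest is a 3.8-fold higher number from compound 2 to compound 3 (0.58 log units; beyond the scatter) with cyclopropyl in place of ethyl on an amide-type nitrogen, and it is modest. The other is a 2.0-fold higher number from compound 1 to compound 3 (0.31 log units; beyond the scatter) with cyclopropylamino in place of diethylamino, and it is also modest. Both rise on reaching cyclopropyl, while the remaining step, a 1.9-fold lower number from compound 1 to compound 2 (0.27 log units; within the scatter) with hydrogen in place of ethyl, shows no change that can be told from noise. Among the measured compounds shown here, no methyl compound has been measured, so the argument rests on these three compounds alone. Leaving cyclopropyl should therefore reverse part of that rise. The expected step is a 2.6-fold lower number from compound 3 to compound 4 (0.41 log units; beyond the scatter) in this assay and it is expected to be modest and towards a lower number. Compound 4 is estimated at 45000 nM with 20000 nM and 100000 nM as the expected ends of its range.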

Compound 4, half-maximal inhibitory concentration: 76500 nM
Beside the measured number, compound 4's estimate is 1.7-fold (0.23 log units) below it, within the range that was stated.
By their numbers in this assay, from the lowest: compounds 2, 1, 4 and 3 (each within the scatter of the next, the first and the last beyond it).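

In this assay, the move from cyclopropyl to methyl on the amide-type nitrogen gives a 1.5-fold lower number from compound 3 to compound 4 (0.18 log units; within the scatter), so these two groups cannot be told apart at this position, and the rise seen on reaching cyclopropyl from ethyl does not mark cyclopropyl alone. Among the compounds shown here, the step that does stand clear is a 2.5-fold higher number from compound 2 to compound 4 (0.40 log units; beyond the scatter), which shows that shortening ethyl to methyl costs about as much as the other measured change away from ethyl, leaving the single ethyl of compound 2 apart from both methyl and cyclopropyl; compound 1 goes against any simple reading, since its diethylamino group gives a 1.3-fold higher number from compound 1 to compound 4 (0.13 log units; within the scatter) and also lies within the scatter of compound 2. No measured evidence bears on the reason for this behaviour at the nitrogen.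

The compounds shown leave open whether a longer chain on this nitrogen, such as propyl or butyl, would continue the trend from methyl to ethyl or reverse it. They also leave open how a chain ending in an amine or a carboxylic acid would behave at the same place.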